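A few compounds are considered here, and "the series" means these few. Any claim that something is new, unique, unknown or untested is made for them only; others in the source may bear on it.

Measured compounds:
- compound 1 `CO[C@H]1C[C@H](O[Si](C)(C)C(C)(C)C)O[C@@H](C)/C1=C\C=N\O`: in a functional assay on the whole organism for inhibition, with Artemia salina as the target (a higher number here means a weaker inhibitor of growth, a lower number a stronger inhibitor of growth), compound 1 gives 0.002 ug/mL
- compound 2 `CO[C@H]1C[C@H](O[Si](C)(C)C(C)(C)C)O[C@@H](C)/C1=C/CCl`: in this assay compound 2 gives 0.01 ug/mL
- compound 3 `CCOC(=O)/C=C1/[C@H](C)O[C@@H](O[Si](C)(C)C(C)(C)C)C[C@@H]1OC`: in this assay compound 3 gives 0.01 ug/mL

Compound 1 stands lowest of the three numbers, and its gap to compound 2 and to compound 3 lies beyond the usual scatter, so it is the strongest inhibitor of growth among the measured compounds. Compound 4 `CO/N=C/C=C1\[C@H](C)O[C@@H](O[Si](C)(C)C(C)(C)C)C[C@@H]1OC` is built from compound 1 by a single change: methyl in place of hydrogen on an oxygen. Among the compounds with values here, no measured step touches this position. Within the data shown here, the only measured step, no change at the digits printed from compound 2 to compound 3 (within the scatter), concerns a different group on a double-bonded chain carbon and shows that a swap out on that chain can leave the number where it was; it is a weak hint, since it does not involve the oxygen in question. With no closer comparison, the expectation for compound 4 is a step of a number one two-fold dilution higher from compound 1 to compound 4 (within the scatter), a small weakening if any, not clearly beyond the scatter. The estimate for compound 4 is therefore 0.004 ug/mL, with a range from 0.001 ug/mL to 0.02 ug/mL.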

Compound 4, minimum inhibitory concentration: 0.01 ug/mL
The estimate for compound 4 lay 1.3 two-fold dilutions below the measured number, within the range that was stated.
By their numbers in this assay, from the lowest: compound 1; then compounds 2, 3 and 4 (each within the scatter of the next).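

In this assay, the change from hydroxy to methoxy gives a number 2.3 two-fold dilutions higher from compound 1 to compound 4 (beyond the scatter), so this oxygen is a place where a single added methyl can be read in the result. Within the data shown here, the only earlier step, no change at the digits printed from compound 2 to compound 3 (within the scatter), concerned a different group on the chain and left this oxygen untouched, so it could not show that the hydrogen here counts for anything. The hydroxy form in compound 1 is now better than its methoxy counterpart by a modest margin, although nothing measured here gives the cause.

On these data alone, an ethyl group or a longer chain on this oxygen remains open, so it cannot be said whether a larger group would weaken the inhibitor further. As far as these compounds go, an amine in place of the hydroxy on the double-bonded nitrogen is also open, and it would test whether a hydrogen on the atom at this place is enough.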